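This account rests on a few compounds, and the source may have more. Where it says the series, first, only, none or still open, it means among the compounds named here.

Of the compounds shown here, three have numbers so far: compound 1 (`COc1cc(OC)c2sc(-c3ccc(N/C=C\C(=O)c4ccc(OC)c([N+](=O)[O-])c4)cc3)nc2c1`), compound 2 (`COc1cc(OC)c2sc(-c3ccc(N/C=C\C(=O)c4cc(OC)c(OC)c([N+](=O)[O-])c4)c(C)c3)nc2c1`) and compound 3 (`COc1cc(C(=O)/C=C\Nc2ccc(-c3nc4cc(OC)c(OC)c(OC)c4s3)cc2)cc([N+](=O)[O-])c1OC`). In a functional assay on A549 cells (Homo sapiens) for antiproliferative activity, read by sulforhodamine B assay, with a stated time of 48 h (on this read-out higher numbers stand for weaker inhibition and lower numbers for stronger inhibition), compound 1 gives 5800 nM, compound 2 gives 15400 nM and compound 3 gives 11800 nM. Compound 3 is therefore second highest of the three; it lies within the scatter of compound 2, and its number lies beyond the scatter above that of compound 1.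

Compound 4 (`COc1cc(OC)c2sc(-c3ccc(N/C=C\C(=O)c4cc(OC)c(OC)c([N+](=O)[O-])c4)cc3)nc2c1`) differs from compound 3 in one place, with hydrogen in place of methoxy on an aromatic carbon. For the measured compounds named here, no measured pair isolates this change, so the expectation in this assay rests on the three values alone. Compound 1 at 5800 nM and compound 2 at 15400 nM both lack that methoxy, and together they bracket the expectation. A small move toward a lower number is expected, most likely within the scatter. The expected step is a 1.3-fold lower number from compound 3 to compound 4 (0.12 log units; within the scatter). For compound 4 the estimated value is 9000 nM, with an expected range from 4500 nM to 18000 nM.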

Compound 4, half-maximal inhibitory concentration: 13000 nM
Beside the measured number, compound 4's estimate is 1.4-fold (0.16 log units) below it; the range from low to high includes it.
By their numbers in this assay, from the lowest: compound 1; then compounds 3, 4 and 2 (each within the scatter of the next).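

In this assay, the first read of the aromatic carbon ortho to two methoxy groups, on the fused system, gives a 1.1-fold higher number from compound 3 to compound 4 (0.04 log units; within the scatter), so methoxy and hydrogen cannot be told apart there at this level of activity. For the compounds shown here, two further single changes set this result in context: loss of the methyl group gives a 1.2-fold lower number from compound 2 to compound 4 (0.07 log units; within the scatter), also without a readable shift, whereas methoxy in place of hydrogen on an aromatic carbon gives a 2.2-fold higher number from compound 1 to compound 4 (0.35 log units; beyond the scatter), the only one of the three steps beyond the scatter, and a modest one. No measurement available explains the size of any of these steps.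

The position has so far been read only with hydrogen and methoxy. From the compounds shown here alone, an amine, a hydroxyl or a longer alkoxy chain there remains open, as does whether any substituent at this carbon can shift the number beyond the scatter.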